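A few compounds are considered here, and "the series" means these few. Any claim that something is new, unique, unknown or untested is made for them only; others in the source may bear on it.

Measured so far:
Compound 1 `O=C(/C=C1\CCc2ccc(F)cc21)NCC1CC1`: 21%
Compound 2 `CNC(=O)/C=C1\CCc2ccc(F)cc21`: 38%

Among the measured compounds shown here, in a functional assay on the whole organism with Rattus norvegicus as the target, at a dose of 20 mg/kg by the oral route (a higher number here means more inhibition at the dose given (going by the name of the read-out), a lower number less inhibition), compound 2 stands highest of the two numbers known, the nearest being compound 1, which lies a number 17 percentage points higher from compound 1 to compound 2 (beyond the scatter) away. Compound 3 `CCCNC(=O)/C=C1\CCc2ccc(F)cc21` is not yet measured; it differs from compound 2 by ethyl in place of hydrogen on a saturated chain carbon bound to an amide-type nitrogen, so a larger group again sits where the cyclopropyl once was. For the measured compounds named here, the one step that bears on this, a number 17 percentage points higher from compound 1 to compound 2 (beyond the scatter), went upward when the larger group left. Since ethyl brings back part of that bulk, a modest downward step is expected, a number 10 percentage points lower from compound 2 to compound 3 (within the scatter). Compound 3 is therefore estimated at 28%, within 12% to 45%.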

Compound 3, a percentage reported as inhibition, in the whole organism at one dose (the size of the read-out at that dose, not a potency): 36%
Estimate against measurement, compound 3: 8 percentage points below; measured number inside the range.
By their numbers in this assay, from the lowest: compound 1; then compounds 3 and 2 (each within the scatter of the next).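

In this assay, ethyl in place of hydrogen on a saturated chain carbon bound to an amide-type nitrogen gives a number 2 percentage points lower from compound 2 to compound 3 (within the scatter), so adding a chain at this position need not lower the number. Ethyl in place of cyclopropyl gives a number 15 percentage points higher from compound 1 to compound 3 (beyond the scatter), so the lower number of compound 1 does not come with every group added here, and cyclopropyl stands apart from ethyl. No measurement at hand explains this difference. Still open, from the compounds shown here alone, is how a longer chain such as butyl would read in this assay, and whether an amine or a carboxylic acid at the chain end would keep the number.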